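The compounds below may be only part of what the source reports. "The series", "measured", "known", "first", "only" and "open" are said of these compounds alone.

Working notes on the biphenyl carboxamide series.

Two compounds have been run so far in an in vitro functional assay on HEK ts201 cells for antagonist activity at Neuronal acetylcholine receptor; alpha4/beta2 (Homo sapiens), read by fluorescence and calcium flux; a higher number here means a weaker inhibitor, a lower number a stronger inhibitor. Compound 1 `O=C(NCc1cccc2ccccc12)c1ccccc1-c1ccccc1` gives 13900 nM in this assay. Compound 2 `O=C(NCc1ccccc1)c1ccccc1-c1ccccc1` gives 7500 nM in this assay. Among the measured compounds shown here, no step between the two is computed here; the two numbers lie within the scatter of each other, so neither compound can be called the stronger or the weaker inhibitor on this evidence, and compound 2 is simply the point from which the next change is taken.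

The next compound is compound 3 `O=C(Nc1ccccn1)c1ccccc1-c1ccccc1`, which has not yet been measured in this assay. Relative to compound 2 the change is pyridin-2-yl in place of benzyl on an amide-type nitrogen. For the measured compounds named here, no measured pair shows what such a change does, so there is no step to lean on. Within this assay the step from compound 2 to compound 3 is expected to be small, with no clear direction beyond the scatter, a 1.3-fold higher number from compound 2 to compound 3 (0.12 log units; within the scatter). Compound 3 is accordingly estimated at 10000 nM in this assay, within a range from 3000 nM to 30000 nM, pending the measurement.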

Compound 3, half-maximal inhibitory concentration: 13600 nM
Beside the measured number, compound 3's estimate is 1.4-fold (0.13 log units) below it; measured number inside the range.
By their numbers in this assay, from the lowest: compounds 2, 3 and 1 (each within the scatter of the next).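

In this assay, the amide-type nitrogen now has its first measured step: pyridin-2-yl in place of benzyl gives a 1.8-fold higher number from compound 2 to compound 3 (0.26 log units; within the scatter), which lies within the scatter. On this pair, replacing a benzyl group of 7 heavy atoms and 0 hydrogen-bond acceptors with a pyridin-2-yl group of 6 heavy atoms and 1 hydrogen-bond acceptor does not separate compound 2 from compound 3, so neither can be called the stronger or weaker inhibitor. No supporting evidence bears on this result, and the pair alone cannot show which of the differences between the two groups matters, if any does.

What the compounds shown leave open is whether any group on this nitrogen can give a step beyond the scatter, since each group shown there carries an aromatic ring; a saturated piperidine ring, a chain ending in a primary amine or one ending in a carboxylic acid would test this. Also open, from the compounds shown here alone, is whether a pyridin-3-yl or pyridin-4-yl group would give a number within the scatter of compound 3.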